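A few compounds are considered here, and "the series" means these few. Any claim that something is new, unique, unknown or untested is made for them only; others in the source may bear on it.

Measured compounds:
compound 1, `OC[C@H]1O[C@@H](n2cnc3c(NCc4ccc(F)cc4)ncnc32)[C@H](O)[C@@H]1O` — "not determined" (no result reported)
compound 2, `OC[C@H]1O[C@@H](n2cnc3c(NCc4ccccc4Cl)ncnc32)[C@H](O)[C@@H]1O` — > 166000 nM (a limit)

In a functional assay on B16 cells (Mus musculus) for antiproliferative activity, with a stated time of 72 h (on this read-out lower numbers stand for stronger inhibition and higher numbers for weaker inhibition), compound 1 has no reported result, so it stands on no number of its own. In this assay compound 2 reaches only a limit, > 166000 nM. Among the compounds with values here, the one further value shown is this limit, (the limit of > 166000 nM in this assay, at which 1 of the 2 values shown sits), and it is the sole anchor for the series.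

Compound 3, `COc1cccc(CNc2ncnc3c2ncn3[C@@H]2O[C@H](CO)[C@@H](O)[C@H]2O)c1O`, is not yet measured. It differs from compound 1 by 2-hydroxy-3-methoxyphenyl in place of 4-fluorophenyl on a saturated chain carbon bound to a nitrogen on an aromatic ring, a change that swaps one aromatic ring bearing a single substituent for one bearing a hydroxy and a methoxy group. Within the data shown here, with no measured step between any two compounds, the size and direction of the change in this assay cannot be read from the data; the only guide is that compound 2 sits at the limit. On that basis compound 3 is expected to show weak inhibition, estimated at 100000 nM with a range from 20000 nM to 300000 nM.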

Compound 3, half-maximal inhibitory concentration: > 166000 nM
Compound 3 ended at the assay's limit; the forecaster's own chance of this, stated with the estimate: 50%; at least 1.6-fold (0.22 log units) between middle value and limit.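

Within the data shown here, compound 2 and compound 3 both end at a limit in this assay, so no step between them can be read: the limit of > 166000 nM in this assay, at which 2 of the 3 values shown sit. The compounds shown leave open whether, in this assay, any aromatic group at this place would give a number rather than a limit.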